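Aromatic ring variation on a shared core

The source may report more compounds than this note shows. Statements on the series, on what has been measured and on what is new or still open speak of the compounds shown alone.

Three analogues share one core and differ only in the aromatic ring attached to the ring nitrogen. Compound 1 `CN1CCN(CCCOc2cccc3nc(Nc4ccc(Cl)c(C(F)(F)F)c4)ccc23)CC1` gives 1380 nM in a functional assay on cells (Panel leukemia (Carcinoma cell lines), Homo sapiens) for inhibition, read by sulforhodamine B assay, with a stated time of 48 h; on this read-out lower numbers stand for stronger inhibition of growth and higher numbers for weaker inhibition of growth. Compound 2 `CN1CCN(CCCOc2cccc3nc(Nc4ccc(F)c(F)c4)ccc23)CC1` gives 2600 nM in this assay, and compound 3 `CN1CCN(CCCOc2cccc3nc(Nc4cc(Cl)cc(Cl)c4)ccc23)CC1` gives 1800 nM in this assay. Compound 3 thus holds the second highest of the three numbers; its nearest neighbour is compound 1 and its furthest is compound 2, and the steps of a 1.3-fold higher number from compound 1 to compound 3 (0.12 log units; within the scatter) and a 1.4-fold lower number from compound 2 to compound 3 (0.16 log units; within the scatter) both sit within the scatter, as does a 1.9-fold higher number from compound 1 to compound 2 (0.28 log units; within the scatter). None of the three ring swaps moved the read-out beyond the scatter.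

Compound 4 `CN1CCN(CCCOc2cccc3nc(Nc4cccc(Cl)c4)ccc23)CC1` differs from compound 3 by hydrogen in place of chloro on an aromatic carbon, that is 3,5-dichlorophenyl to 3-chlorophenyl. Among the compounds with values here, no measured pair isolates the removal of a single chloro from this ring; the bearing evidence is only the three swaps above, each within the scatter. The expectation for compound 4 is therefore no step beyond the scatter in this assay, with a 1.2-fold higher number from compound 3 to compound 4 (0.09 log units; within the scatter) as the estimated step. Compound 4 is estimated at 2200 nM, with a range from 900 nM to 5500 nM.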

Compound 4, concentration for 50% growth inhibition: 1990 nM
Compound 4: the middle estimate sits 1.1-fold (0.04 log units) above what was measured; low and high end bracket the measured number.
By their numbers in this assay, from the lowest: compounds 1, 3, 4 and 2 (each within the scatter of the next).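

Within the data shown here, compound 4 gives the first pair that isolates a single chloro on this ring: in this assay there is a 1.1-fold higher number from compound 3 to compound 4 (0.04 log units; within the scatter), so on the 3,5-dichlorophenyl ring a chloro meta to a chloro group gives way to hydrogen with no step beyond the scatter. The 3-chlorophenyl ring also stays within the scatter of the two more heavily substituted rings, with a 1.3-fold lower number from compound 2 to compound 4 (0.12 log units; within the scatter) and a 1.4-fold higher number from compound 1 to compound 4 (0.16 log units; within the scatter), so all four rings shown remain unresolved from one another on this read-out, and a single chloro serves as well here as the richer halogen patterns. No separate measurement on these compounds accompanies this flat picture, and its origin cannot be stated from the data shown.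

Going by these compounds, whether an unsubstituted phenyl, or a ring carrying a methoxy group, an amine or a carboxylic acid, would stay within the scatter of these four remains open. Also open, on these data alone, is whether a longer chain on the ether oxygen of the shared core would move the read-out further than any change on this ring has.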